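The source may hold more compounds than are shown below. What is called first, only, known or untested is meant among the compounds shown, and "the series" means these compounds.

Compound 1 `Cc1cc(=O)oc2cc(OCc3cn(-c4ccc(Cl)cc4)nn3)ccc12` is the reference point of this set. In an ADME assay on Huh-7 cells (Homo sapiens) for cytotoxicity, read by MTT assay, with a stated time of 72 h (a lower number here means that less compound is tolerated, a higher number that more compound is tolerated), compound 1 gives > 100 ug/mL, which is a limit of the assay rather than a number. Compound 2 `Cc1cc(=O)oc2cc(OCc3cn(-c4ccc(OC(F)(F)F)cc4)nn3)ccc12` carries trifluoromethoxy in place of chloro on an aromatic carbon. In this assay compound 2 gives > 100 ug/mL, again a limit of the assay. For the measured compounds named here, the one step measured so far, a step that the two limits leave unreadable from compound 1 to compound 2, therefore cannot be sized; both values sit at the limit of > 100 ug/mL in this assay, at which 2 of the 2 values shown sit. Compound 3 `Cc1cc(F)ccc1-n1cc(COc2ccc3c(C)cc(=O)oc3c2)nn1` differs from compound 1 by 4-fluoro-2-methylphenyl in place of 4-chlorophenyl on an aromatic nitrogen. Going by the values given here, no measured step bears directly on this change, and the single aryl-ring variation in hand stayed at the limit, so no movement beyond the scatter is anticipated. The step from compound 1 to compound 3 is expected to be a number no higher from compound 1 to compound 3 (the limit leaves the size open). For compound 3 in this assay the estimate is 100 ug/mL, within a range of 40 ug/mL to 300 ug/mL.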

Compound 3, half-maximal cytotoxic concentration: > 100 ug/mL
Compound 3: a limit, no number; the forecaster's own chance of this, stated with the estimate: 85%; the middle value lies on the limit itself.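

In this assay, for the compounds shown here, compound 3 gives > 100 ug/mL, a limit of the assay, and no step from compound 1 to compound 3 can be read: the limit of > 100 ug/mL in this assay, at which 3 of the 3 values shown sit. The compounds shown leave open the actual half-maximal cytotoxic concentration of each, and whether any change on the aryl ring alters it.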